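Alkyne terminus change from compound 1 to compound 4

The compounds below may be only part of what the source reports. "The series", "measured", "known", "first", "only" and "open" are said of these compounds alone.

Measured compounds so far:
Compound 1 `O=[N+]([O-])c1c(CS(=O)(=O)c2ccccc2)nc2c(C#Cc3ccccc3)cc(Cl)cn12` gives > 3900 nM in an ADME assay on HepG2 cells (Homo sapiens) for cytotoxicity, read by MTT assay, with a stated time of 72 h (a higher number here means that more compound is tolerated, a lower number that less compound is tolerated), a limit of the assay.
Compound 2 `COc1cccc(C#Cc2cc(Cl)cn3c([N+](=O)[O-])c(CS(=O)(=O)c4ccccc4)nc23)c1` gives > 3900 nM in this assay, a limit of the assay.
Compound 3 `O=[N+]([O-])c1c(CS(=O)(=O)c2ccccc2)nc2c(C#Cc3ccccc3F)cc(Cl)cn12` gives > 3900 nM in this assay, a limit of the assay.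

Compound 1 stands only at a limit, and the same holds for the two other values shown (the limit of > 3900 nM in this assay, at which 3 of the 3 values shown sit). The three measured steps are therefore all unreadable: a step that the two limits leave unreadable from compound 1 to compound 2 for methoxy in place of hydrogen on an aromatic carbon, a step that the two limits leave unreadable from compound 1 to compound 3 for fluoro in place of hydrogen on an aromatic carbon, and a step that the two limits leave unreadable from compound 2 to compound 3 for 2-fluorophenyl in place of 3-methoxyphenyl on a triple-bonded carbon.

Compound 4 `O=[N+]([O-])c1c(CS(=O)(=O)c2ccccc2)nc2c(C#CCCO)cc(Cl)cn12` differs from compound 1 as follows: 2-hydroxyethyl in place of phenyl on a triple-bonded carbon. Among the compounds with values here, of the measured steps, only the one from compound 2 to compound 3 changes the group on the triple-bonded carbon, and it too is unreadable. There is no readable step in this assay on which to build a direction, so no step beyond the scatter is expected; the estimate for the step is a step that the limit leaves unreadable from compound 1 to compound 4, and a further limit is the likely outcome. Compound 4 is expected to give about 4500 nM in this assay, within 2500 nM to 12000 nM.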

Compound 4, half-maximal cytotoxic concentration: > 125000 nM
Compound 4: only a limit was reported (the forecaster's own chance of this, stated with the estimate: 85%); at least 27-fold (1.44 log units) between middle value and limit.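

Within the data shown here, compound 1, compound 2, compound 3 and compound 4 all stand only at limits of the assay in this assay, and no step to compound 4 can be read. The compounds shown leave open at what concentration any of them reaches the half-maximal cytotoxic read-out, and whether 2-hydroxyethyl in place of phenyl shifts it.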